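Swapping the Carbamoyl Group on the Pyrrolidine Nitrogen

The compounds below may be only part of what the source reports. "The series", "measured", "known", "first", "only" and "open" are said of these compounds alone.

Compound 1 `CC(C)(C)OC(=O)N1CCC[C@H]1C(=O)N1CCC(NS(=O)(=O)c2cc(S(=O)(=O)c3ccccc3)ccc2C(F)(F)F)CC1` gives 60 nM in an assay on isolated protein for binding affinity to secreted frizzled-related protein 1 (Homo sapiens), read by fluorescence; on this read-out higher numbers stand for weaker inhibition and lower numbers for stronger inhibition. Compound 2 `CC(=O)N1CCC[C@H]1C(=O)N1CCC(NS(=O)(=O)c2cc(S(=O)(=O)c3ccccc3)ccc2C(F)(F)F)CC1` gives 160 nM. Compound 3 `CCNC(=O)N1CCC[C@H]1C(=O)N1CCC(NS(=O)(=O)c2cc(S(=O)(=O)c3ccccc3)ccc2C(F)(F)F)CC1` gives 30 nM.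

Of these three numbers, compound 3 has the lowest. Its gap to compound 1, a 2.0-fold lower number from compound 1 to compound 3 (0.30 log units; within the scatter), lies within the usual scatter, so the two cannot be ranked against each other; the step of a 5.3-fold lower number from compound 2 to compound 3 (0.73 log units; beyond the scatter) is beyond the scatter, as is a 2.7-fold higher number from compound 1 to compound 2 (0.43 log units; beyond the scatter).

Compound 4 `O=C([C@@H]1CCCN1Cc1ccccc1)N1CCC(NS(=O)(=O)c2cc(S(=O)(=O)c3ccccc3)ccc2C(F)(F)F)CC1` has not yet been measured. It differs from compound 3 in one place: benzyl in place of ethylcarbamoyl on an amine nitrogen in a ring. Within the data shown here, none of the measured steps bears directly on this change. All three measured compounds keep a carbonyl attached to that ring nitrogen, and the steps between them only exchange the group on the carbonyl carbon. The change to compound 4 is therefore a jump beyond what the measured steps cover, and the estimate is uncertain. A modestly higher number is expected for compound 4, with 150 nM and a range from 40 nM to 600 nM. This corresponds to an expected step of a 5.0-fold higher number from compound 3 to compound 4 (0.70 log units; beyond the scatter).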

Compound 4, half-maximal inhibitory concentration: 1400 nM
For compound 4 the middle estimate is 9.3-fold (0.97 log units) below the measured one; measured number above the stated range.
By their numbers in this assay, from the lowest: compounds 3 and 1 (each within the scatter of the next); then compound 2; then compound 4.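

All three earlier compounds keep a carbonyl on the ring nitrogen, so they show only what the group on that carbonyl does, while compound 4, with benzyl, shows the result of having no carbonyl there. In this assay benzyl gives a higher number than each of the carbonyl-bearing groups: a 47-fold higher number from compound 3 to compound 4 (1.67 log units; beyond the scatter) against ethylcarbamoyl and a 23-fold higher number from compound 1 to compound 4 (1.37 log units; beyond the scatter) against tert-butoxycarbonyl, and even acetyl, which had the highest number before, gives way to an 8.8-fold higher number from compound 2 to compound 4 (0.94 log units; beyond the scatter) here. Nothing available explains this rise.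

Benzyl differs in two ways at once, since it brings an aromatic ring and lacks the carbonyl, and these compounds cannot separate the two. A benzoyl group, which has both the carbonyl and the ring, and a plain ethyl group, which has neither, would each help to tell them apart.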